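The source may hold more compounds than are shown below. What is called first, only, known or untested is meant among the compounds shown, and "the series" means these compounds.

In a functional assay on U-87MG ATCC cells for antiproliferative activity against U-87 MG (Homo sapiens), read by MTT assay, with a stated time of 48 h (on this read-out higher numbers stand for weaker inhibition and lower numbers for stronger inhibition), compound 2 (`Cc1nc(-c2ccccc2)sc1C(=O)CSc1nc(-c2cccc(Cl)c2)c(C#N)c(=O)[nH]1`) gives 28200 nM and compound 1 (`COc1ccc(-c2nc(SCC(=O)c3sc(-c4ccccc4)nc3C)[nH]c(=O)c2C#N)cc1`) gives 48400 nM. These two values sit within the scatter of each other, so compound 2 cannot yet be ranked against compound 1. Compound 3 (`COc1ccc(-c2nc(SCC(=O)c3sc(-c4ccccc4)nc3C)[nH]c(=O)c2C#N)cc1OC`) carries 3,4-dimethoxyphenyl in place of 3-chlorophenyl on an aromatic carbon next to the ring nitrogen: 3,4-dimethoxyphenyl in place of 3-chlorophenyl on an aromatic carbon. Within the data shown here, only one measured step bears on this change. That step, a 1.7-fold lower number from compound 1 to compound 2 (0.23 log units; within the scatter), exchanged one group for another at the same place and stayed small. A single step of that size points in no clear direction, so no step beyond the scatter is expected in this assay here. The estimate corresponds to an expected 1.3-fold higher number from compound 2 to compound 3 (0.13 log units; within the scatter) in this read-out. Compound 3 is estimated at 38000 nM, with a range from 15000 nM to 95000 nM expected.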

Compound 3, half-maximal inhibitory concentration: 15300 nM
The estimate for compound 3 lay 2.5-fold (0.40 log units) above the measured number; the range from low to high includes it.
By their numbers in this assay, from the lowest: compounds 3, 2 and 1 (each within the scatter of the next, the first and the last beyond it).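

In this assay, among these compounds, methoxy in place of hydrogen on the aromatic carbon of the phenyl ring gives a 3.2-fold lower number from compound 1 to compound 3 (0.50 log units; beyond the scatter), the first step at this place to clear the scatter, although only modestly. The exchange of 3-chlorophenyl for 3,4-dimethoxyphenyl, by contrast, gives a 1.8-fold lower number from compound 2 to compound 3 (0.27 log units; within the scatter), so these two groups cannot be ranked in this assay. No available evidence gives a reason for either result.

Going by these compounds, it remains open whether the lower number needs both methoxy groups or whether 3-methoxyphenyl alone would match it. The compounds shown also leave open how a phenyl ring carrying an amine or a carboxylic acid would behave at this place, and all three keep the rest of the molecule unchanged.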